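Replacing nitro with hydroxy on compound 3

The compounds below may be only part of what the source reports. "The series", "measured", "known", "first", "only" and "open" are said of these compounds alone.

In a functional assay on KB cells (Homo sapiens) for antiproliferative activity, read by MTT assay, with a stated time of 72 h (on this read-out higher numbers stand for weaker inhibition and lower numbers for stronger inhibition), compound 1 (`COc1ccc(-c2sc(C(=O)O)cc2-c2cc(OC)c(OC)c(OC)c2)cc1[N+](=O)[O-]`) gives 35900 nM, compound 2 (`CCOC(=O)c1cc(-c2ccc(OC)c([N+](=O)[O-])c2)c(-c2cc(OC)c(OC)c(OC)c2)s1`) gives 24000 nM and compound 3 (`COc1ccc(-c2cc(C(=O)O)sc2-c2cc(OC)c(OC)c(OC)c2)cc1[N+](=O)[O-]`) stands at 43700 nM alongside them. These three numbers lie within the usual scatter of one another, so compound 3 cannot be ranked against the other two. Among the measured compounds shown here, the only measured step (a 1.8-fold higher number from compound 2 to compound 3 (0.26 log units; within the scatter)) exchanges ethyl for hydrogen at the ester and stays within that scatter.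

Compound 4 (`COc1ccc(-c2cc(C(=O)O)sc2-c2cc(OC)c(OC)c(OC)c2)cc1O`) keeps the core of compound 3 but carries hydroxy in place of nitro on an aromatic carbon. For the measured compounds named here, no measured step touches this spot, so the ester step is only a loose guide and the data fix neither the size nor the direction of the change. A modest step toward stronger inhibition is expected in this assay (a 2.9-fold lower number from compound 3 to compound 4 (0.46 log units; beyond the scatter)), but this is a judgement and not a measured trend, so the range is kept wide. For compound 4 the estimated value is 15000 nM (expected range from 1500 nM to 50000 nM).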

Compound 4, half-maximal inhibitory concentration: 21800 nM
Estimate against measurement, compound 4: 1.5-fold (0.16 log units) below; measured number inside the range.
By their numbers in this assay, from the lowest: compounds 4, 2, 1 and 3 (each within the scatter of the next).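

Among the compounds shown here, this position is now probed for the first time, and in this assay the exchange of nitro for hydroxy gives a 2.0-fold lower number from compound 3 to compound 4 (0.30 log units; within the scatter). On this evidence the spot, ortho to a methoxy group, accepts a group of 1 heavy atom with a hydrogen-bond donor in place of one with 3 heavy atoms and no donor, without the two compounds being told apart. No evidence at hand offers an explanation for this result.

One exchange at this spot cannot show whether any group there can shift the number beyond the usual scatter, so an amine or a fluorine atom in the same place would test this further. From the compounds shown here alone, it also remains open whether hydroxy would behave in the same way alongside the ethyl ester of compound 2.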